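Macrophage cytotoxicity of benzyl-substituted analogues on the shared core

The source may hold more compounds than are shown below. What is called first, only, known or untested is meant among the compounds shown, and "the series" means these compounds.

Measured so far:
compound 1, `CC1(Cc2ccccc2)CC(S(=O)(=O)c2ccc(F)cc2)=C(c2ccc(/C(N)=N/O)cc2)O1`, 102000 nM
compound 2, `CC1(Cc2ccc(C(F)(F)F)cc2)CC(S(=O)(=O)c2ccc(F)cc2)=C(c2ccc(/C(N)=N/O)cc2)O1`, 103000 nM

In an ADME assay on cells (Peritoneal macrophage, Mus musculus, strain Balb/c) for cytotoxicity, read by resazurin assay, with a stated time of 72 h (a lower number here means that less compound is tolerated, a higher number that more compound is tolerated), compound 1 gives 102000 nM, the lowest of the two numbers, with compound 2 at 103000 nM; the step is a 1.0-fold higher number from compound 1 to compound 2 (0.00 log units; within the scatter). Compound 3, `CC1(Cc2cccc(CO)c2)CC(S(=O)(=O)c2ccc(F)cc2)=C(c2ccc(/C(N)=N/O)cc2)O1`, is not yet measured; it differs from compound 1 by hydroxymethyl in place of hydrogen on an aromatic carbon. Among the measured compounds shown here, the only step that bears on it is the one on the same benzyl ring, from compound 1 to compound 2, which changed nothing beyond the scatter. No step beyond the scatter is therefore expected in this assay. Compound 3 is estimated at 100000 nM (range 50000 nM to 200000 nM), an expected step of a 1.0-fold lower number from compound 1 to compound 3 (0.01 log units; within the scatter).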

Compound 3, half-maximal cytotoxic concentration: > 100000 nM
Compound 3 gave a limit, no number (the forecaster's own chance of this, stated with the estimate: 15%); the middle value lies on the limit itself.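

Compound 3 gives only a limit and not a number, so no step from compound 1 or compound 2 to compound 3 can be read: the limit of > 100000 nM in this assay, at which 1 of the 3 values shown sits.

As far as these compounds go, whether hydroxymethyl in place of hydrogen separates compound 3 from compound 1 beyond the scatter stays open.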